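Thiophene Sulfonyl Replaces Benzodioxin on the Piperidine Amide

The source may report more compounds than this note shows. Statements on the series, on what has been measured and on what is new or still open speak of the compounds shown alone.

Compound 3 `CCN(Cc1ccccc1)C(=O)C1CCN(S(=O)(=O)c2cccc3c2OCCO3)CC1` gives the lowest of the three responses recorded so far. In a functional assay on CHO cells for positive allosteric modulation of muscarinic acetylcholine receptor M5 (Homo sapiens), read by calcium flux (a lower number here means a smaller maximal response, a higher number a larger maximal response), compound 3 gives 53%. Compound 1 `CCN(Cc1ccccc1)C(=O)C1CCN(S(=O)(=O)c2ccccc2)CC1` gives 69%, and compound 2 `CCN(Cc1ccccc1)C(=O)C1CCN(S(=O)(=O)c2ccc(OC)c(OC)c2)CC1` gives 57%. The two steps leading to compound 3 differ in size: a number 16 percentage points lower from compound 1 to compound 3 (beyond the scatter), whereas a number 4 percentage points lower from compound 2 to compound 3 (within the scatter). Compound 4 `CCN(Cc1ccccc1)C(=O)C1CCN(S(=O)(=O)c2ccc(C)s2)CC1` carries a different group on the sulfonyl sulfur: 5-methylthiophen-2-yl in place of 2,3-dihydro-1,4-benzodioxin-5-yl on a sulfonyl sulfur. Within the data shown here, no measured step exchanges the aryl group for a five-membered heteroaryl, and the steps at this position were modest or within the scatter, so compound 4 is expected to move only a little in this assay. The expected step is a number 7 percentage points higher from compound 3 to compound 4 (within the scatter). Compound 4 is thus estimated at 60%, between 45% and 75%.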

Compound 4, largest response reached (reported as percent of maximum), in percent of the reference or control that the assay uses: 64%
The estimate for compound 4 lay 4 percentage points below the measured number, within the range that was stated.
By their numbers in this assay, from the lowest: compounds 3, 2, 4 and 1 (each within the scatter of the next, the first and the last beyond it).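

In this assay the change to 5-methylthiophen-2-yl gives a number 11 percentage points higher from compound 3 to compound 4 (beyond the scatter) and a number 7 percentage points higher from compound 2 to compound 4 (within the scatter) and also a number 5 percentage points lower from compound 1 to compound 4 (within the scatter). Among these compounds, a six-membered aromatic ring of carbon only is therefore not needed on the sulfonyl sulfur, since a five-membered aromatic ring with one hetero atom keeps the response within the scatter of compound 1. No measurement available here accounts for these differences.

Going by these compounds, what the methyl group contributes to 5-methylthiophen-2-yl remains open, as does the response with a pyridinyl or cyclohexyl group on the sulfonyl sulfur.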